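Mirror-image pyrrolidine: the step from compound 3 to compound 4

A few compounds are considered here, and "the series" means these few. Any claim that something is new, unique, unknown or untested is made for them only; others in the source may bear on it.

The measured compounds:
compound 1, `O=C(c1ccccc1)N1CCC(NS(=O)(=O)c2cc(S(=O)(=O)c3ccccc3)ccc2C(F)(F)F)CC1`: 250 nM
compound 2, `O=C(c1ccc(Cl)nc1)N1CCC(NS(=O)(=O)c2cc(S(=O)(=O)c3ccccc3)ccc2C(F)(F)F)CC1`: 140 nM
compound 3, `CC(C)(C)OC(=O)N1CC[C@H](C(=O)N2CCC(NS(=O)(=O)c3cc(S(=O)(=O)c4ccccc4)ccc3C(F)(F)F)CC2)C1`: 150 nM

All three numbers come from an assay on U2OS cells for inhibition of secreted frizzled-related protein 1 (Homo sapiens), read by a luciferase reporter, with a stated time of 18 h; a higher number here means that more compound is needed for the effect, a lower number that less compound is needed. Compound 1 gives 250 nM, compound 2 gives 140 nM and compound 3 gives 150 nM. Compound 3 sits between the other two, and every step among them is within the usual scatter: a 1.8-fold lower number from compound 1 to compound 2 (0.25 log units; within the scatter), a 1.7-fold lower number from compound 1 to compound 3 (0.22 log units; within the scatter) and a 1.1-fold higher number from compound 2 to compound 3 (0.03 log units; within the scatter).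

Compound 4, `CC(C)(C)OC(=O)N1CC[C@@H](C(=O)N2CCC(NS(=O)(=O)c3cc(S(=O)(=O)c4ccccc4)ccc3C(F)(F)F)CC2)C1`, has not yet been measured. Its difference from compound 3 is the two compounds have the same atoms and bonds and differ only in configuration as drawn: 1 of 1 stereo elements differ; a stereocentre at a saturated ring carbon is drawn S in compound 3 and R in compound 4. For the measured compounds named here, no measured step here changes a stereocentre; the three measured steps all swap the group on the carbonyl carbon and all stay within the scatter, so they say nothing directly about mirror-image forms. With no guide from the data, the expectation for compound 4 in this assay is a number near that of compound 3, with a wide range on either side, expressed as a 1.3-fold higher number from compound 3 to compound 4 (0.12 log units; within the scatter). Compound 4 is therefore estimated at 200 nM, between 60 nM and 700 nM.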

Compound 4, half-maximal effective concentration: 80 nM
Estimate against measurement, compound 4: 2.5-fold (0.40 log units) above, within the range that was stated.
By their numbers in this assay, from the lowest: compounds 4, 2, 3 and 1 (each within the scatter of the next, the first and the last beyond it).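

In this assay, inverting the stereocentre at a saturated ring carbon from S to R gives a 1.9-fold lower number from compound 3 to compound 4 (0.27 log units; within the scatter), so at this position the change of configuration does not carry the number clear of the usual scatter. For the compounds shown here, with the R form of the 1-(tert-butoxycarbonyl)pyrrolidin-3-yl group on the carbonyl carbon, replacing 6-chloropyridin-3-yl gives a 1.8-fold lower number from compound 2 to compound 4 (0.24 log units; within the scatter), while replacing phenyl gives a 3.1-fold lower number from compound 1 to compound 4 (0.49 log units; beyond the scatter), the first step in this set to pass the scatter, and a modest one. Any gap within the mirror-image pair can have only one source: the fact that compounds 3 and 4 differ only in the configuration as drawn.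

From the compounds shown here alone, what a free amine or an acetyl group in place of the tert-butoxycarbonyl group would do to either form remains open. So does whether the gap between the S and R forms would widen or vanish with such a group.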